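Swapping a Thiophene for Phenyl on a Shared Core

A few compounds are considered here, and "the series" means these few. Any claim that something is new, unique, unknown or untested is made for them only; others in the source may bear on it.

Within the data shown here, compound 3 `Cc1ccccc1-n1nc(C)c2c1NC(=O)[C@H](C)S[C@@H]2c1ccc(-c2ccsc2)cc1` gives 1400 nM in an assay on isolated protein for agonist activity at Bile acid receptor (Homo sapiens), read by AlphaScreen, with a stated time of 30 min (on this read-out lower numbers stand for an effect already at smaller amounts and higher numbers for an effect only at larger amounts of compound), the lowest of the three numbers measured so far. Compound 1 `COc1ccccc1-n1nc(C)c2c1NC(=O)[C@H](C)S[C@@H]2c1ccc(Oc2ccccc2)cc1` gives 3300 nM in this assay, and compound 2 `Cc1ccc(-n2nc(C)c3c2NC(=O)[C@H](C)S[C@@H]3c2ccc(Oc3ccccc3)cc2)cc1` gives 3400 nM; both of these stand beyond the scatter away from compound 3. Among the measured compounds shown here, the only step measured between close neighbours, a 1.0-fold higher number from compound 1 to compound 2 (0.01 log units; within the scatter), concerns the aryl group on the aromatic nitrogen and lies within the scatter. Compound 4 `Cc1ccccc1-n1nc(C)c2c1NC(=O)[C@H](C)S[C@@H]2c1ccc(-c2ccccc2)cc1` differs from compound 3 in one place: phenyl in place of thiophen-3-yl on an aromatic carbon. For the measured compounds named here, no measured step touches this position, so nothing measured bears directly on the change. With no guidance from a measured step, the change is expected to amount to a 1.3-fold higher number from compound 3 to compound 4 (0.11 log units; within the scatter), a step within the scatter. Compound 4 is therefore estimated at 1800 nM, with a range from 700 nM to 4500 nM.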

Compound 4, half-maximal effective concentration: 990 nM
The estimate for compound 4 lay 1.8-fold (0.26 log units) above the measured number; the range from low to high includes it.
By their numbers in this assay, from the lowest: compounds 4 and 3 (each within the scatter of the next); then compounds 1 and 2 (each within the scatter of the next).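

Among these compounds, the first measured step at this place, on an aromatic carbon of the six-membered aromatic ring, is small (a 1.4-fold lower number from compound 3 to compound 4 (0.15 log units; within the scatter)), so compound 3 and compound 4 cannot be told apart in this assay. For this pair, a six-membered aromatic ring of carbon only serves as well as a five-membered aromatic ring holding sulfur. No measurement is available to explain this match.

Still open, going by these compounds, is how an amine, a carboxylic acid or a cyclohexyl group would fare at this place. Also open, on these data alone, is whether the phenyl and thiophen-3-yl groups would match with another aryl group on the aromatic nitrogen.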